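Cyano in place of ethoxycarbonyl on compound 2

The source may report more compounds than this note shows. Statements on the series, on what has been measured and on what is new or still open speak of the compounds shown alone.

In a functional assay (uterus) for inhibition, with Rattus norvegicus as the target (on this read-out lower numbers stand for an effect already at smaller amounts and higher numbers for an effect only at larger amounts of compound), compound 1 (`CCOC(=O)c1[nH]c2nccnc2c1C`) gives 0.102 nM and compound 2 (`CCOC(=O)c1cn2c(Br)cncc2n1`) gives 1.02 nM as the higher of two numbers on this read-out, a gap beyond the scatter. Compound 3 (`N#Cc1cn2c(Br)cncc2n1`) has cyano in place of ethoxycarbonyl on an aromatic carbon. Among the measured compounds shown here, both measured compounds carry ethoxycarbonyl, and no measured step covers this replacement. The expected step of a 3.9-fold higher number from compound 2 to compound 3 (0.59 log units; beyond the scatter) in this assay runs toward a higher number, beyond the scatter, though its size remains a rough estimate. For compound 3 the estimated value is 4 nM with an expected range of 0.6 nM to 25 nM in this assay.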

Compound 3, concentration for half-maximal effect: 0.78 nM
Compound 3: the middle estimate sits 5.1-fold (0.71 log units) above what was measured; the measured number falls inside the stated range.
By their numbers in this assay, from the lowest: compound 1; then compounds 3 and 2 (each within the scatter of the next).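

In this assay, the step of a 1.3-fold lower number from compound 2 to compound 3 (0.12 log units; within the scatter) shows that ethoxycarbonyl is not needed on this aromatic carbon of the five-membered aromatic ring: cyano, with fewer heavy atoms and no oxygen, reads the same within the scatter. Among the compounds shown here, both earlier compounds carried ethoxycarbonyl, so this is the first sign that the position tolerates a change of group on the core of compound 2. No supporting data bear on why the two groups read alike. Still open, on these data alone, is how a carboxylic acid, a primary amide or an amine would read at this position. As far as these compounds go, whether cyano in place of ethoxycarbonyl on the core of compound 1 gives a similar step also remains open.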